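Growth inhibition limits in a small carboxylic acid series

The source may hold more compounds than are shown below. What is called first, only, known or untested is meant among the compounds shown, and "the series" means these compounds.

Measured in a functional assay on HT-29 cells (Homo sapiens) for inhibition, read by sulforhodamine B assay, with a stated time of 48 h; on this read-out lower numbers stand for stronger inhibition of growth and higher numbers for weaker inhibition of growth:
- compound 1 `CC(C)(C)NCc1c(C(=O)O)nn(-c2ccccc2)c1-c1ccc(F)cc1`: > 680000 nM, a limit
- compound 2 `CC(C)(C)NCc1c(C(=O)O)nn(-c2ccc(Cl)cc2)c1-c1ccc(F)cc1`: > 623000 nM, a limit

Compound 2 stands at > 623000 nM, which is a limit. For the measured compounds named here, compound 1 also gave only a limit, so the series has no measured number so far.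

Compound 3 `COc1ccc(-c2c(CNC(C)(C)C)c(C(=O)O)nn2-c2ccc(Cl)cc2)cc1` keeps the core of compound 2 and differs in one group: methoxy in place of fluoro on an aromatic carbon. This is methoxy in place of fluoro on an aromatic carbon, 4-fluorophenyl to 4-methoxyphenyl. Going by the values given here, the only measured step is a step that the two limits leave unreadable from compound 1 to compound 2. It is a different change and gives no size to carry over, so no step beyond the scatter is expected. Since compound 2 offers only the limit > 623000 nM, compound 3 is expected to show weak growth inhibition in this assay, most likely reported as a limit again. The expected change is an at least 1.0-fold lower number from compound 2 to compound 3 (0.01 log units; that floor lies within the scatter). For compound 3 the estimated value is 600000 nM, with an expected range of 250000 nM to 1000000 nM.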

Compound 3, concentration for 50% growth inhibition: > 605000 nM
Compound 3 gave a limit, no number; the forecaster's own chance of this, stated with the estimate: 85%; middle value at least 1.0-fold (0.00 log units) from the limit.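

In this assay compound 3 gives > 605000 nM, a limit; compound 2 also gave only a limit, so no step can be read between compound 2 and compound 3. The compounds shown leave open whether any change on the shared core yields a readable growth inhibition number.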